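Exposure in monkey after swapping a hydroxymethyl for a sulfonylcarbamoyl

A few compounds are considered here, and "the series" means these few. Any claim that something is new, unique, unknown or untested is made for them only; others in the source may bear on it.

Of the compounds shown here, three sharing one core have been measured in an ADME assay on the whole organism (Macaca fascicularis) for pharmacokinetics, read by LC-MS, using cassette dosing, at a dose of 1 mg/kg by the oral route; a higher number here means more compound in the circulation at the dose given, a lower number less compound in the circulation. Compound 1 `CCCCN(c1nc2c(NS(C)(=O)=O)cccc2o1)[C@H](C)c1ccc(-c2ccccc2-c2nnn[nH]2)cc1` gives 49.9 nM. Compound 2 `CCCCN(c1nc2c(C(=O)NC)cccc2o1)[C@H](C)c1ccc(-c2ccccc2-c2nnn[nH]2)cc1` gives 19.7 nM, and compound 3 `CCCCN(c1nc2c(CO)cccc2o1)[C@H](C)c1ccc(-c2ccccc2-c2nnn[nH]2)cc1` gives 20.7 nM. Compound 3 thus stands second highest of the three: its gap to compound 2 is within the scatter, while compound 1 sits clearly higher, as the step of a 2.4-fold lower number from compound 1 to compound 3 (0.38 log units; beyond the scatter) shows. The comparable step a 1.1-fold higher number from compound 2 to compound 3 (0.02 log units; within the scatter) is within the scatter.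

Compound 4 `CCCCN(c1nc2c(C(=O)NS(C)(=O)=O)cccc2o1)[C@H](C)c1ccc(-c2ccccc2-c2nnn[nH]2)cc1` differs from compound 3 in one place: (methylsulfonyl)carbamoyl in place of hydroxymethyl on an aromatic carbon. The new group carries a methylsulfonyl, as in compound 1, and a carbamoyl, as in compound 2. The two measured steps that bear on this spot were modest in one case and flat in the other, so a step of modest size at most in this assay, if anything upward toward the number of compound 1, is expected for compound 4. Compound 4 is therefore expected to give about 28 nM, with a range from 9 nM to 85 nM, meaning an expected step of a 1.4-fold higher number from compound 3 to compound 4 (0.13 log units; within the scatter).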

Compound 4, maximal plasma concentration: 40.4 nM
For compound 4 the middle estimate is 1.4-fold (0.16 log units) below the measured one; the measured number falls inside the stated range.
By their numbers in this assay, from the lowest: compounds 2, 3, 4 and 1 (each within the scatter of the next, the first and the last beyond it).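

In this assay, among the compounds shown here, a methylsulfonyl in place of the methyl on the amide-type nitrogen gives a 2.1-fold higher number from compound 2 to compound 4 (0.31 log units; beyond the scatter) and so marks a change at this position that stands clear of the scatter, which the earlier compounds could not show. The (methylsulfonyl)carbamoyl in place of hydroxymethyl gives a 2.0-fold higher number from compound 3 to compound 4 (0.29 log units; within the scatter) and in place of methanesulfonamido gives a 1.2-fold lower number from compound 1 to compound 4 (0.09 log units; within the scatter), so neither of these two gaps can be told from the scatter. Nothing available here gives a reason for these numbers. That clear step rests on a single pair of compounds, so it cannot yet be called a pattern. Open too, on these data alone, is where a carboxylic acid on this aromatic carbon, or an ethylsulfonyl or longer chain on the sulfonyl in place of the methyl, would fall.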